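Extending the Amino Group of Compound 2 with a Hydroxyethyl Chain

This account rests on a few compounds, and the source may have more. Where it says the series, first, only, none or still open, it means among the compounds named here.

Compound 1, `C/N=C1/S[C@@H]([C@H](C)c2c[nH]c3ccccc23)C(=O)N1C`, in an ADME assay on BHK cells (Mesocricetus auratus) for cytotoxicity; a lower number here means that less compound is tolerated, a higher number that more compound is tolerated: 4 ug/mL
Compound 2, `C[C@H](c1c[nH]c2ccccc12)[C@@H]1SC(N)=NC1=O`, in this assay: 100 ug/mL

Of the two measured compounds, compound 2 stands highest in this assay, meaning the cells tolerate more of it; compound 1 sits far below, and the gap between the two lies well beyond the scatter of repeated measurements. Compound 3, `C[C@H](c1c[nH]c2ccccc12)[C@@H]1SC(NCCO)=NC1=O`, has not yet been measured. It differs from compound 2 in one place: 2-hydroxyethyl in place of hydrogen on an amine nitrogen. Within the data shown here, no step between two measured compounds that differ in a single place is available, so there is no direct precedent for this kind of change, and the one measured pair changes more than one feature at once. The expectation rests on compound 2 alone, because compound 2 gives 100 ug/mL and the change is a modest addition of a short chain. The step from compound 2 to compound 3 is expected to be small and most likely downward, at or near the edge of the scatter: a 1.7-fold lower number from compound 2 to compound 3 (0.22 log units; within the scatter). Compound 3 is therefore estimated at 60 ug/mL, with a range from 20 ug/mL to 150 ug/mL.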

Compound 3, minimum cytotoxic concentration: 100 ug/mL
Compound 3: middle estimate off by 1.7-fold (0.22 log units), on the low side, and the stated range covers the measured number.
By their numbers in this assay, from the lowest: compound 1; then compounds 2 and 3 (each within the scatter of the next).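

In this assay, placing 2-hydroxyethyl in place of hydrogen on an amine nitrogen gives no change at the digits printed from compound 2 to compound 3 (within the scatter). Among these compounds, this is the first measured step that changes one place only, since the earlier pair differs in more than one feature, and it shows that this nitrogen can carry a 2-hydroxyethyl chain with no readable shift in how much compound the cells tolerate. Nothing measured here explains why the number holds steady, so the result stands as an observation without a known cause.

One step with one group at one position cannot show how far this tolerance extends: a longer chain, such as 3-hydroxypropyl, could give a different number, as could a chain ending in a carboxylic acid or an amine. The compounds shown also leave open whether the hydroxyl at the end of the chain plays any part in the result, which a plain ethyl group on the same nitrogen would help to settle.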